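Three sulfonamides at the assay limit, a fourth to come

The source may report more compounds than this note shows. Statements on the series, on what has been measured and on what is new or still open speak of the compounds shown alone.

Compound 1, `Cc1ccccc1S(=O)(=O)Nc1ccc2oc(-c3ccccc3)nc2c1`: in an assay on isolated protein for inhibition of malate dehydrogenase, mitochondrial (Sus scrofa), with stated times of 45 min and 30 min (on this read-out lower numbers stand for stronger inhibition and higher numbers for weaker inhibition), compound 1 gives > 63000 nM, a limit of the assay.
Compound 2, `O=S(=O)(Nc1ccc2oc(-c3ccccc3)nc2c1)c1ccc(O)cc1`: in this assay compound 2 gives > 63000 nM, a limit of the assay.
Compound 3, `CCc1ccc(S(=O)(=O)Nc2ccc3oc(-c4ccccc4)nc3c2)cc1`: in this assay compound 3 gives > 63000 nM, a limit of the assay.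

The three compounds share one core and differ only in the aryl group on the sulfonyl sulfur. Compound 3 stands at a limit, and the two other values are limits as well (the limit of > 63000 nM in this assay, at which 3 of the 3 values shown sit), so the steps a step that the two limits leave unreadable from compound 1 to compound 2, a step that the two limits leave unreadable from compound 1 to compound 3 and a step that the two limits leave unreadable from compound 2 to compound 3 cannot be read in size or direction.

Compound 4, `O=S(=O)(Nc1ccc2oc(-c3ccccc3)nc2c1)c1ccccc1O`, differs from compound 3 by 2-hydroxyphenyl in place of 4-ethylphenyl on a sulfonyl sulfur. Among the measured compounds shown here, the steps that bear on this change are those in which a hydroxy group enters the aryl ring or the 4-ethylphenyl group is exchanged, and all of them are unreadable. No step size in this assay can therefore be derived from the data, and compound 4 is expected to remain at the limit as well.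

Compound 4 is estimated to give 80000 nM in this assay, within 20000 nM to 300000 nM. The expected step that the limit leaves unreadable from compound 3 to compound 4 thus amounts to no readable change.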

Compound 4, half-maximal inhibitory concentration: > 63000 nM
Compound 4: only a limit was reported; the forecaster's own chance of this, stated with the estimate: 85%; the middle value is on the limit's open side.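

Compound 4 also stands at a limit of the assay, so its steps from compound 1, compound 2 and compound 3 cannot be read in size or direction: the limit of > 63000 nM in this assay, at which 4 of the 4 values shown sit. The compounds shown leave open how strongly any of them inhibits in this assay, and whether the aryl group on the sulfonyl sulfur matters at all.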